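Swapping a Methoxyphenyl Arm for a Methoxyphenoxy Arm

A few compounds are considered here, and "the series" means these few. Any claim that something is new, unique, unknown or untested is made for them only; others in the source may bear on it.

Of the compounds shown here, two with a shared core have been measured. Compound 1 `COc1cccc(-c2ccc([C@H]3S[C@@H](C)C(=O)Nc4c3c(C)nn4-c3ccccc3C)cc2)c1` gives 41% in an assay on isolated protein for agonist activity at Bile acid receptor (Homo sapiens), read by AlphaScreen, with a stated time of 30 min; on this read-out lower numbers stand for smaller maximal responses and higher numbers for larger maximal responses. Compound 2 `COc1ccccc1-c1ccc([C@H]2S[C@@H](C)C(=O)Nc3c2c(C)nn3-c2ccccc2C)cc1` gives 50% in this assay. For the measured compounds named here, the one measured step, a number 9 percentage points higher from compound 1 to compound 2 (within the scatter), lies within the scatter, so compound 2 stands at the larger of the two numbers without being separable from compound 1. Compound 3 `COc1ccc(Oc2ccc([C@H]3S[C@@H](C)C(=O)Nc4c3c(C)nn4-c3ccccc3C)cc2)cc1` has not yet been measured. It differs from compound 2 in one place: 4-methoxyphenoxy in place of 2-methoxyphenyl on an aromatic carbon. Going by the values given here, no measured step covers an exchange of this kind, and the single step from compound 1 to compound 2 was small, so there is no basis for expecting a large shift in either direction. The step of a number 5 percentage points lower from compound 2 to compound 3 (within the scatter) is therefore expected to stay within the scatter. Compound 3 is estimated to give 45% in this assay, with a likely range from 25% to 65%.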

Compound 3, largest response reached (reported as efficacy), in percent of the reference or control that the assay uses: 70%
Estimate against measurement, compound 3: 25 percentage points below; the measured number lies above the stated range.
By their numbers in this assay, from the lowest: compounds 1 and 2 (each within the scatter of the next); then compound 3.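

In this assay, this position proves able to change the maximal response: exchanging the aryl arm for 4-methoxyphenoxy gives a number 20 percentage points higher from compound 2 to compound 3 (beyond the scatter) and a number 29 percentage points higher from compound 1 to compound 3 (beyond the scatter) as well. For the compounds shown here, the earlier exchange between 3-methoxyphenyl and 2-methoxyphenyl gave no separable difference, so compound 3 provides the first change here that stands clear of the scatter, and it holds against both methoxyphenyl compounds. Nothing shown explains why the methoxyphenoxy arm gives the larger response.

The exchange alters both the attachment of the ring, through an added oxygen, and the place of the methoxy group, so the two contributions cannot be told apart from these compounds. A 4-methoxyphenyl arm and a plain phenoxy arm would separate them, and a 3-methoxyphenoxy or 2-methoxyphenoxy arm would show whether the methoxy place still matters.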